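Acrylamide series: phenyl in place of methyl

The source may report more compounds than this note shows. Statements on the series, on what has been measured and on what is new or still open speak of the compounds shown alone.

Measured so far in a functional assay on MOLT-4 cells (Homo sapiens) for cytotoxicity, read by CCK-8 assay, with a stated time of 24 h; a lower number here means a stronger inhibitor, a higher number a weaker inhibitor:
Compound 1 `C=CC(=O)N1C(=O)CC(c2ccc(C(F)(F)F)cc2)Sc2ccccc21` gives 76300 nM.
Compound 2 `C=CC(=O)N1C(=O)CC(C)Sc2ccccc21` gives 730000 nM.

Compound 2 holds the higher of the two numbers; compound 1 lies well below it, a gap beyond the scatter. Compound 3 `C=CC(=O)N1C(=O)CC(c2ccccc2)Sc2ccccc21` is not yet measured. It differs from compound 2 as follows: phenyl in place of methyl on a saturated ring carbon. A step toward a lower number, beyond the scatter, is expected because compound 1 gives 76300 nM with a trifluoromethyl-bearing phenyl where compound 2 has the methyl. Compound 3 is estimated at 150000 nM, with a range from 50000 nM to 500000 nM. The expected step is a 4.9-fold lower number from compound 2 to compound 3 (0.69 log units; beyond the scatter).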

Compound 3, half-maximal inhibitory concentration: 85900 nM
For compound 3 the middle estimate is 1.7-fold (0.24 log units) above the measured one; low and high end bracket the measured number.
By their numbers in this assay, from the lowest: compounds 1 and 3 (each within the scatter of the next); then compound 2.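

Phenyl in place of methyl on the saturated ring carbon next to the ring sulfur gives an 8.5-fold lower number from compound 2 to compound 3 (0.93 log units; beyond the scatter) in this assay, so the unsubstituted phenyl alone accounts for this drop. Hydrogen in place of trifluoromethyl on an aromatic carbon gives a 1.1-fold higher number from compound 1 to compound 3 (0.05 log units; within the scatter), so the trifluoromethyl adds nothing this assay can resolve. Nothing available explains either step.

Open, as far as these compounds go, is whether a cyclohexyl or benzyl group on this ring carbon would match phenyl. Also open, from the compounds shown here alone, is whether an amine or methoxy group on the phenyl would move the number beyond the scatter.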